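This account rests on a few compounds, and the source may have more. Where it says the series, first, only, none or still open, it means among the compounds named here.

Compound 1 `CC(=O)OCc1ccc2oc(=O)c(C(=O)Oc3cccc(Br)c3)cc2c1` gives 21.8% in a functional assay on HT-1080 cells (Homo sapiens), read by transwell migration, with a stated time of 24 h, tested at 1 uM; on this read-out higher numbers stand for a weaker effect at the one concentration tested and lower numbers for a stronger effect. Compound 2 `CC(=O)OCc1ccc2oc(=O)c(C(=O)Sc3ccccc3)cc2c1` gives 83.5% in this assay. Compound 3 `CC(=O)OCc1ccc2oc(=O)c(C(=O)N(C)c3cccc(Cl)c3)cc2c1` gives 82.6% in this assay.

Among these three numbers compound 1 stands lowest: the step of a number 61.7 percentage points higher from compound 1 to compound 2 (beyond the scatter) and the step of a number 60.8 percentage points higher from compound 1 to compound 3 (beyond the scatter) are both large, while the step of a number 0.9 percentage points lower from compound 2 to compound 3 (within the scatter) lies within the scatter. Compound 4 `CC(C)(C)C(=O)OCc1ccc2oc(=O)c(C(=O)Oc3cccc(Br)c3)cc2c1` differs from compound 1 in one place: tert-butyl in place of methyl on a carbonyl carbon. Going by the values given here, no measured step touches this place; each of the three known steps alters the group on the other carbonyl carbon, so none of them speaks directly to this change. With nothing bearing on it, a step of a number 4.2 percentage points higher from compound 1 to compound 4 (within the scatter) in this assay is expected, that is, none beyond the scatter. Compound 4 is therefore estimated at 26%, within 12% to 48%.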

Compound 4, a percentage reported as activity, at one concentration (the size of the read-out at that concentration, not a potency): 48.2%
Compound 4: middle estimate off by 22.2 percentage points, on the low side; measured number outside the range, above it.
By their numbers in this assay, from the lowest: compound 1; then compound 4; then compounds 3 and 2 (each within the scatter of the next).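

Going by these compounds alone, changing the far end of the acetoxymethyl group, which no earlier step touched, does register in this assay: tert-butyl in place of methyl on a carbonyl carbon gives a number 26.4 percentage points higher from compound 1 to compound 4 (beyond the scatter), a weaker effect at the one concentration tested. This step is modest, whereas both steps on the other carbonyl carbon were large. Nothing available explains this change.

From the compounds shown here alone, it remains open whether an ethyl or isopropyl group here would give a number closer to that of compound 1. Going by these compounds, it is also open whether tert-butyl would have a similar effect alongside the phenylsulfanyl or (3-chlorophenyl)(methyl)amino groups.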